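The source may hold more compounds than are shown below. What is called first, only, known or untested is meant among the compounds shown, and "the series" means these compounds.

Measured in an ADME assay on HCT-116 cells (Homo sapiens) for cytotoxicity, read by CellTiter-Glo, with a stated time of 72 h; on this read-out lower numbers stand for stronger inhibition and higher numbers for weaker inhibition:
Compound 1 `CC1CCN(C2CCN(S(=O)(=O)c3ccc(C#N)cc3)CC2)CC1`: > 5000 nM (a limit, not a number)
Compound 2 `CCc1ccc(S(=O)(=O)N2CCC(N3CCC(C)CC3)CC2)cc1`: > 5000 nM (a limit, not a number)

Compound 2 has no numerical potency on this read-out: > 5000 nM is a limit of the assay. It shares that position with the only other measured compound, as shown by the limit of > 5000 nM in this assay, at which 2 of the 2 values shown sit.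

The next change leads to compound 3 `CC1CCN(C2CCN(S(=O)(=O)c3ccc(C(C)C)cc3)CC2)CC1`. The difference is methyl in place of hydrogen on a saturated chain carbon bound to an aromatic carbon and a saturated chain carbon. In words, methyl replaces hydrogen on a saturated chain carbon bound to an aromatic carbon and a saturated chain carbon, turning ethyl into isopropyl.

Among the compounds with values here, one measured step bears on this change, a step that the two limits leave unreadable from compound 1 to compound 2. It also alters a group on an aromatic carbon, but it gives no size to carry forward. With no readable step as a guide, no change beyond the scatter is expected in this assay, and no direction can be assigned. A further report as a limit is the likeliest result.

The expected step is a step that the limit leaves unreadable from compound 2 to compound 3. For compound 3 the estimate is 7000 nM, with an expected range of 3000 nM to 20000 nM.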

Compound 3, half-maximal inhibitory concentration: > 5000 nM
Compound 3 ended at the assay's limit; the forecaster's own chance of this, stated with the estimate: 85%; the middle value does not contradict the limit.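

In this assay compound 3 gives > 5000 nM, a limit and not a number. No step can be read among compound 1, compound 2 and compound 3, because all three sit at the same limit: the limit of > 5000 nM in this assay, at which 3 of the 3 values shown sit. The compounds shown leave open where their actual potencies lie and whether the group on the aromatic carbon shifts them.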